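Trifluoroethoxy to isopropylsulfanyl: an expected cytotoxicity outcome

This account rests on a few compounds, and the source may have more. Where it says the series, first, only, none or still open, it means among the compounds named here.

Of the compounds shown here, three on a shared core have been tested in an ADME assay on MOLT-3 cells (Homo sapiens) for cytotoxicity, with a stated time of 7 days; a higher number here means that more compound is tolerated, a lower number that less compound is tolerated. In this assay compound 1 `CCCCCCCCOc1nc(N)nc2c1ncn2/C=C1/CC1(CO)CO` gives > 20000 nM, which is a limit of the assay rather than a measured number. Compound 2 `Nc1nc(OCC(F)(F)F)c2ncn(/C=C3/CC3(CO)CO)c2n1` likewise gives > 20000 nM, again only a limit. Compound 3 `Nc1nc2c(ncn2/C=C2/CC2(CO)CO)c(=O)[nH]1` also reaches just the limit, > 20000 nM. Going by the values given here, the single step between compounds that differ in one place, trifluoromethyl in place of heptyl on a saturated chain carbon bound to an oxygen on an aromatic ring, is a step that the two limits leave unreadable from compound 1 to compound 2; both of its ends are limits, and its size is not readable. Compound 2 thus stands where every value shown stands, at the limit of > 20000 nM in this assay, at which 3 of the 3 values shown sit.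

Compound 4 `CC(C)Sc1nc(N)nc2c1ncn2/C=C1/CC1(CO)CO` has not yet been measured. It differs from compound 2 by isopropylsulfanyl in place of 2,2,2-trifluoroethoxy on an aromatic carbon. Among the compounds with values here, the only measured step that touches this position is the unreadable one, and all three measured compounds sit at the same limit, so no step beyond the usual scatter is expected here. Compound 4 is therefore estimated at 25000 nM, with a range from 10000 nM to 60000 nM, and is most likely to be reported again only as a limit. This estimate means an expected step that the limit leaves unreadable from compound 2 to compound 4.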

Compound 4, half-maximal cytotoxic concentration: > 20000 nM
Compound 4 ended at the assay's limit (the forecaster's own chance of this, stated with the estimate: 85%); the middle value is on the limit's open side.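

Compound 4 gives > 20000 nM in this assay, which is a limit and not a number, so the steps to it from compound 1 and compound 2 cannot be read. The compounds shown leave open what concentration of any of them would reach the half-maximal cytotoxic effect, and whether swapping these groups changes it: the limit of > 20000 nM in this assay, at which 4 of the 4 values shown sit.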